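Notes on amide variation in the trifluoromethyl series

This account rests on a few compounds, and the source may have more. Where it says the series, first, only, none or still open, it means among the compounds named here.

Of the compounds shown here, two have been measured in an assay on HEK293 cells for displacement of a labelled ligand from Melanocortin receptor 4 (Homo sapiens); a lower number here means a stronger inhibitor, a higher number a weaker inhibitor. Compound 1 `CC(C)C[C@H](N)c1cc(C(F)(F)F)ccc1N1CCN(C(=O)COc2ccc3ccccc3c2)CC1` gives 2000 nM; compound 2 `CC(C)C[C@H](N)c1cc(C(F)(F)F)ccc1N1CCN(C(=O)COc2ccc([N+](=O)[O-])cc2)CC1` gives 3100 nM. For the measured compounds named here, the one step between them, a 1.6-fold higher number from compound 1 to compound 2 (0.19 log units; within the scatter), falls within the scatter, so compound 2 and compound 1 stand on a par, with no ordering that the numbers can support.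

Compound 3 `Cc1cc(CC(C)C(=O)N2CCN(c3ccc(C(F)(F)F)cc3[C@@H](N)CC(C)C)CC2)ccc1Cl` is not yet measured. It differs from compound 2 as follows: 1-(4-chloro-3-methylbenzyl)ethyl in place of (4-nitrophenoxy)methyl on a carbonyl carbon. Going by the values given here, no measured step bears on this change; the only step recorded, a 1.6-fold higher number from compound 1 to compound 2 (0.19 log units; within the scatter), alters the aromatic ring on the oxygen and leaves the carbonyl substituent otherwise intact, whereas here the whole (4-nitrophenoxy)methyl group is exchanged. Without a guiding step, no direction beyond the scatter is expected, but the uncertainty is wide. Compound 3 is estimated at 2500 nM, within 500 nM to 12000 nM, which means an expected step of a 1.2-fold lower number from compound 2 to compound 3 (0.09 log units; within the scatter).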

Compound 3, inhibition constant: 71 nM
The estimate for compound 3 lay 35-fold (1.55 log units) above the measured number, outside the stated range (below it).
By their numbers in this assay, from the lowest: compound 3; then compounds 1 and 2 (each within the scatter of the next).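

In this assay the group on the carbonyl carbon proves to be a sensitive place: 1-(4-chloro-3-methylbenzyl)ethyl in place of (4-nitrophenoxy)methyl gives a 44-fold lower number from compound 2 to compound 3 (1.64 log units; beyond the scatter) and the same group in place of ((naphthalen-2-yl)oxy)methyl gives a 28-fold lower number from compound 1 to compound 3 (1.45 log units; beyond the scatter) while the earlier change of the aromatic ring on the oxygen stayed within the scatter. The heavy-atom count stays the same across the first of these changes, whereas the entering group has no hydrogen-bond acceptors against 3 in the leaving group. No supporting measurement accounts for this result.

Which part of the entering group carries the step remains open, as the chlorine, the ring methyl and the chain methyl all enter together. Also open, as far as these compounds go, is how a plain benzyl group or a carboxylic acid on this carbonyl carbon would stand in this assay.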